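This account rests on a few compounds, and the source may have more. Where it says the series, first, only, none or still open, it means among the compounds named here.

Among the measured compounds shown here, in a functional assay on HepG2 cells (Homo sapiens) for antiproliferative activity, read by MTT assay, with a stated time of 48 h (a higher number here means a weaker inhibitor, a lower number a stronger inhibitor), the two compounds measured so far give no number at all. Compound 1, with the structure `CC(=O)Nc1ccc(-n2nncc2CN2C(=O)C3(C(C#N)=C(N)Oc4c(N)cc5nc6ccccc6nc5c43)c3ccccc32)cc1`, gives only the limit > 50000 nM in this assay. Compound 2, with the structure `N#CC1=C(N)Oc2c(N)cc3nc4ccccc4nc3c2C12C(=O)N(Cc1cnnn1-c1ccc([N+](=O)[O-])cc1)c1ccccc12`, likewise gives only the limit > 50000 nM. The step from compound 1 to compound 2, a nitro in place of acetamido on an aromatic carbon, therefore comes out as a step that the two limits leave unreadable from compound 1 to compound 2, which follows from the limit of > 50000 nM in this assay, at which 2 of the 2 values shown sit. So compound 2 stands at the edge of what this assay can report, and nothing measured here tells how far beyond that edge it lies.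

Compound 3, with the structure `CCc1cccc(C)c1-n1nncc1CN1C(=O)C2(C(C#N)=C(N)Oc3c(N)cc4nc5ccccc5nc4c32)c2ccccc21`, differs from compound 2 by 2-ethyl-6-methylphenyl in place of 4-nitrophenyl on an aromatic nitrogen. For the measured compounds named here, no measured step bears on this change: the only step known here is the unreadable one from compound 1 to compound 2, and it concerns a different part of the molecule. With both neighbours sitting at the limit, the most likely outcome is that compound 3 is also expected to sit at or near that limit, with a step that the limit leaves unreadable from compound 2 to compound 3 expected as the step from compound 2. The estimate for compound 3 is therefore 60000 nM, within a range from 15000 nM to 200000 nM, with a good chance that only a limit is reported.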

Compound 3, half-maximal inhibitory concentration: > 50000 nM
Compound 3 gave a limit, no number (the forecaster's own chance of this, stated with the estimate: 75%); the middle value is on the limit's open side.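

Compound 3 in this assay gives > 50000 nM as a limit, not a number. The steps from compound 1 and from compound 2 to compound 3 therefore cannot be read: the limit of > 50000 nM in this assay, at which 3 of the 3 values shown sit. The compounds shown leave open how far beyond the limit each one lies, and whether any other group on that aromatic nitrogen would give a measurable value.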